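A Fluorine-Bearing Acid Chain in Place of Compound 2's

The source may hold more compounds than are shown below. What is called first, only, known or untested is meant among the compounds shown, and "the series" means these compounds.

In an ADME assay on the whole organism (Rattus norvegicus, strain Sprague-Dawley) for pharmacokinetics, read by LC-MS (a lower number here means that more of the compound stays in the plasma, a higher number that more of the compound sits outside the plasma), compound 1 (`COc1ccc(F)c([C@H]2CC[C@H](COc3cccc([C@@H](CC(=O)O)C4CC4)c3)CC2)c1`) gives 0.2 L/kg and compound 2 (`COc1ccc(F)c([C@H]2CC[C@H](COc3cccc([C@H](C4CC4)[C@H](C)C(=O)O)c3)CC2)c1`) gives 0.9 L/kg as the higher of the two numbers. Compound 3 (`COc1ccc(F)c([C@H]2CC[C@H](COc3cccc([C@H](C4CC4)[C@@H](F)C(=O)O)c3)CC2)c1`) is still unmeasured. It differs from compound 2 by carboxy(fluoro)methyl in place of 1-carboxyethyl on a saturated chain carbon bound to an aromatic carbon and a saturated ring carbon with carboxy(fluoro)methyl in place of 1-carboxyethyl on a saturated chain carbon bound to an aromatic carbon and a saturated ring carbon. Within the data shown here, the one measured step that bears on this is a 4.5-fold higher number from compound 1 to compound 2 (0.65 log units; beyond the scatter) which is modest but beyond the scatter, and it added the methyl that compound 3 no longer has. Part of that rise is therefore expected to be lost, although no fluorine-bearing compound has been measured. The expected change in this assay is a 2.3-fold lower number from compound 2 to compound 3 (0.35 log units; beyond the scatter) and it points toward a lower number. For compound 3 the estimate is 0.4 L/kg with an expected range from 0.2 L/kg to 0.8 L/kg for now.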

Compound 3, volume of distribution at steady state: 0.9 L/kg
Estimate against measurement, compound 3: 2.3-fold (0.35 log units) below; the measured number lies above the stated range.
By their numbers in this assay, from the lowest: compound 1; then compounds 2 and 3 (each within the scatter of the next).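

In this assay the step from 1-carboxyethyl to carboxy(fluoro)methyl on this saturated chain carbon (no change at the digits printed from compound 2 to compound 3 (within the scatter)) shows that losing the methyl does not by itself bring the number down when fluorine takes its place. Read from the unbranched acid chain, fluoro in place of hydrogen (a 4.5-fold higher number from compound 1 to compound 3 (0.65 log units; beyond the scatter)) gives a rise of the same printed size as the one methyl gave, so among these compounds that rise is not unique to methyl. Nothing measured here explains why the two groups land together.

From the compounds shown here alone, whether the number would hold with hydroxy or chloro on that carbon remains open. So does the effect of the opposite arrangement at the stereocentre that carries the fluorine, or of an amide in place of the carboxylic acid.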